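Replacing a fluorophenyl with trifluoromethyl on the shared core

The source may hold more compounds than are shown below. What is called first, only, known or untested is meant among the compounds shown, and "the series" means these compounds.

Three compounds share the core of compound 1 `Cc1n[nH]c(C(=O)O)c1Cc1ccccc1-c1ccc(F)cc1` and have been tested in an assay on isolated protein for inhibition of 2-Hydroxyacid oxidase 2 (Homo sapiens), tested at 10 uM; a lower number here means a weaker effect, a higher number a stronger effect of the compound at the concentration tested. Compound 1 gives 56%, the highest of the three numbers. Compound 2 `Cc1n[nH]c(C(=O)O)c1Cc1cccc(-c2ccc(C#N)cc2)c1` gives 46%, which lies within the scatter of compound 1, so no order between these two can be claimed. Compound 3 `Cc1n[nH]c(C(=O)O)c1Cc1cccc(-c2ccccc2F)c1` gives 22%, well below compound 1. Going by the values given here, the only step measured between two compounds that differ in one place is a number 24 percentage points lower from compound 2 to compound 3 (beyond the scatter), a 2-fluorophenyl in place of 4-cyanophenyl on an aromatic carbon.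

Compound 4 `Cc1n[nH]c(C(=O)O)c1Cc1ccccc1C(F)(F)F` differs from compound 1 as follows: trifluoromethyl in place of 4-fluorophenyl on an aromatic carbon. Among the compounds with values here, no measured step removes a whole aryl group in this way, so the step from compound 2 to compound 3 bears on it only loosely; it shows that changing the distal aryl can move the read-out modestly. Compound 4 is therefore expected to give 35% (range 10% to 60%), an estimated step of a number 21 percentage points lower from compound 1 to compound 4 (beyond the scatter) with wide uncertainty.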

Compound 4, a percentage reported as inhibition, at one concentration (the size of the read-out at that concentration, not a potency): 38%
For compound 4 the middle estimate is 3 percentage points below the measured one, and the stated range covers the measured number.
By their numbers in this assay, from the lowest: compound 3; then compounds 4, 2 and 1 (each within the scatter of the next, the first and the last beyond it).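

Placing trifluoromethyl in the position of the 4-fluorophenyl group gives, in this assay, a number 18 percentage points lower from compound 1 to compound 4 (beyond the scatter). The earlier compounds shown here all carried a second aromatic ring, whereas compound 4 shows that the read-out does not vanish without one at this aromatic carbon, ortho to a large group: compound 4 still gives 38%, although the change costs a step that lies beyond the scatter. Nothing measured here accounts for the size of this step.

The compounds shown do not separate the loss of the ring from the arrival of the trifluoromethyl group, as only one ring-free group stands at this position. On these data alone, how an amine, a longer chain or an unsubstituted phenyl ring would read at the same place in this assay remains open.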